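Acylating the sulfonamide nitrogen of compound 3

This account rests on a few compounds, and the source may have more. Where it says the series, first, only, none or still open, it means among the compounds named here.

Of the compounds shown here, three have been measured in an assay on cells for antagonist activity at transient receptor potential cation channel subfamily V member 1 (Homo sapiens), read by FLIPR and calcium flux, with a stated time of 15 min; a lower number here means a stronger inhibitor, a higher number a weaker inhibitor. Compound 1 `COc1cc(C(C)C(=O)NCc2ccc(C(F)(F)F)nc2N2CCC(C)CC2)ccc1NS(C)(=O)=O` gives 0.8 nM; compound 2 `COc1cc(C(C)C(=O)NCc2ccc(C(F)(F)F)nc2N2CCC(C)CC2)cc(F)c1NS(C)(=O)=O` gives 0.3 nM; compound 3 `CC1CCN(c2nc(C(F)(F)F)ccc2CNC(=O)C(C)c2ccc(NS(=O)(=O)C(C)C)c(F)c2)CC1` gives 8.7 nM, the highest of the three numbers, so it is the weakest inhibitor shown. Within the data shown here, the only single-point step measured, a 2.7-fold lower number from compound 1 to compound 2 (0.43 log units; beyond the scatter), concerns a fluoro group and leaves the sulfonamide untouched.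

Compound 4 `C=CC(=O)N(c1ccc(C(C)C(=O)NCc2ccc(C(F)(F)F)nc2N2CCC(C)CC2)cc1F)S(C)(=O)=O` is made from compound 3 by the change ((methylsulfonyl)(vinylcarbonyl)amino in place of (isopropylsulfonyl)amino on an aromatic carbon). Among the measured compounds shown here, no measured step alters this part of the molecule, so the effect can only be guessed. Compounds 1 and 2 carry a methylsulfonyl group with a free hydrogen and give low numbers, while compound 4 keeps the methylsulfonyl but loses that hydrogen. A modest weakening is therefore expected, with wide uncertainty, giving a 3.4-fold higher number from compound 3 to compound 4 (0.54 log units; beyond the scatter). The estimate for compound 4 is 30 nM, expected to lie between 5 nM and 200 nM.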

Compound 4, inhibition constant: 2.4 nM
Beside the measured number, compound 4's estimate is 13-fold (1.10 log units) above it; measured number below the stated range.
By their numbers in this assay, from the lowest: compound 2; then compound 1; then compound 4; then compound 3.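

In this assay the change gives a 3.6-fold lower number from compound 3 to compound 4 (0.56 log units; beyond the scatter), so the number falls even though the entering (methylsulfonyl)(vinylcarbonyl)amino group has no hydrogen-bond donor and the leaving (isopropylsulfonyl)amino group has one. Among these compounds, compound 1, compound 2 and compound 3 all keep the hydrogen on the sulfonamide nitrogen, so this is the first result to show that, on this scaffold, a low number does not depend on that hydrogen. Nothing shown explains why the number moves in this direction.

On these data alone, the step swaps the isopropyl for a methyl and adds the vinylcarbonyl in one move, so the share of each remains unknown. Also open, as far as these compounds go, is how a saturated acetyl group in place of the vinylcarbonyl would read at this position.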